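The compounds below may be only part of what the source reports. "The series", "measured", "known", "first", "only" and "open" are said of these compounds alone.

Values measured so far in a functional assay on HeLa cells (Homo sapiens) for cytotoxicity, read by ELISA, with a stated time of 4 days; a higher number here means a weaker inhibitor, a lower number a stronger inhibitor
- Compound 1 `Cc1ccsc1-c1cc(-c2ccco2)cc(-c2ccccc2Cl)n1` gives 24000 nM
- Compound 2 `Cc1ccc(-c2cc(-c3ccoc3)cc(-c3ccc(Cl)s3)n2)o1` gives 26500 nM
- Compound 3 `Cc1ccccc1-c1cc(-c2ccoc2)cc(-c2ccc(Cl)s2)n1` gives 19000 nM

Compound 3 at 19000 nM stands level with the other two, since compound 1 and compound 2 both lie within the scatter of it. The next compound to be measured is compound 4 `Clc1ccc(-c2cc(-c3ccoc3)cc(-c3cccnc3)n2)s1` which carries pyridin-3-yl in place of 2-methylphenyl on an aromatic carbon next to the ring nitrogen of the shared core.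

For the measured compounds named here, one measured step bears on this same carbon. Putting 2-methylphenyl there in place of 5-methylfuran-2-yl gave a 1.4-fold lower number from compound 2 to compound 3 (0.14 log units; within the scatter) and so stayed within the scatter. Compound 1 differs from the others in more than one place and offers no single-change comparison. Going by the values given here, the evidence is therefore one small step, and no compound with pyridin-3-yl has been measured yet, so the range has to stay wide. In this assay no step beyond the scatter is expected. The estimate corresponds to an expected 1.2-fold higher number from compound 3 to compound 4 (0.06 log units; within the scatter) and no real separation from compound 3 is anticipated. Compound 4 is estimated at 22000 nM (expected range 10000 nM to 45000 nM).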

Compound 4, half-maximal inhibitory concentration: 20000 nM
For compound 4 the middle estimate is 1.1-fold (0.04 log units) above the measured one; low and high end bracket the measured number.
By their numbers in this assay, from the lowest: compounds 3, 4, 1 and 2 (each within the scatter of the next).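

In this assay, the carbon next to the ring nitrogen of the shared core has now carried three different aromatic rings while the 5-chlorothiophen-2-yl and furan-3-yl groups stayed the same. Pyridin-3-yl, the first of these rings with a hetero atom in a six-membered aromatic ring and with a hydrogen-bond acceptor, gives a 1.1-fold higher number from compound 3 to compound 4 (0.02 log units; within the scatter) against 2-methylphenyl and a 1.3-fold lower number from compound 2 to compound 4 (0.12 log units; within the scatter) against 5-methylfuran-2-yl, so both steps stay within the scatter and the three rings cannot be told apart at this carbon. Nothing available here accounts for this lack of separation.

The compounds shown leave open whether a group of another kind on this carbon, such as an amine, a carboxylic acid or a longer chain, would carry the number in this assay beyond the scatter. They also leave open whether replacing the furan-3-yl or the 5-chlorothiophen-2-yl group, with pyridin-3-yl kept in place, would produce any step larger than those seen so far.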